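The source may report more compounds than this note shows. Statements on the series, on what has been measured and on what is new or still open speak of the compounds shown alone.

For the measured compounds named here, in a functional assay on ECa-109 cells (Homo sapiens) for cytotoxicity, read by MTT assay, with a stated time of 72 h (a lower number here means a stronger inhibitor, a higher number a weaker inhibitor), compound 3 `COc1cccc(C=C2C(=O)N(c3ccc(Cl)cc3)N(c3ccc(Cl)cc3)C2=O)c1O` gives 39000 nM, the highest of the three numbers so far. Compound 1 `COc1cc(C=C2C(=O)N(c3ccc(Cl)cc3)N(c3ccc(Cl)cc3)C2=O)cc(OC)c1OC` gives 10100 nM and compound 2 `COc1cc(C=C2C(=O)N(c3ccc(Cl)cc3)N(c3ccc(Cl)cc3)C2=O)ccc1O` gives 7100 nM, and these two lie within the scatter of each other. Compound 4 `COc1ccc(C=C2C(=O)N(c3ccc(Cl)cc3)N(c3ccc(Cl)cc3)C2=O)cc1OC` is unmeasured and differs from compound 3 by 3,4-dimethoxyphenyl in place of 2-hydroxy-3-methoxyphenyl on a double-bonded chain carbon bound to a double-bonded ring carbon. Going by the values given here, the one measured step that bears on this is a 5.5-fold higher number from compound 2 to compound 3 (0.74 log units; beyond the scatter), where 2-hydroxy-3-methoxyphenyl entered. Compound 4 loses that group, as compound 1 and compound 2 lack it, so a step of similar size toward a lower number is expected in this assay. The estimated step is a 3.9-fold lower number from compound 3 to compound 4 (0.59 log units; beyond the scatter). For compound 4 the expected value is 10000 nM, with an estimated range from 5000 nM to 21000 nM.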

Compound 4, half-maximal inhibitory concentration: > 128000 nM
Compound 4 was reported as a limit; the forecaster's own chance of this, stated with the estimate: 3%; at least 12-fold (1.10 log units) between middle value and limit.
By their numbers in this assay, from the lowest: compounds 2 and 1 (each within the scatter of the next); then compound 3. At a limit, above all of these: compound 4.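

In this assay compound 4 is reported only as a limit, not as a number: the limit of > 128000 nM in this assay, at which 1 of the 4 values shown sits. At this place, 3,4-dimethoxyphenyl in place of 2-hydroxy-3-methoxyphenyl gives an at least 3.2-fold higher number from compound 3 to compound 4 (0.51 log units; beyond the scatter), so losing that group did not bring the number down. Methyl in place of hydrogen on the ring oxygen gives an at least 18-fold higher number from compound 2 to compound 4 (1.25 log units; beyond the scatter), and hydrogen in place of methoxy gives an at least 12-fold higher number from compound 1 to compound 4 (1.10 log units; beyond the scatter), so each single change to the ring matters, and compound 1 shows that a free hydroxy is not required.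

Going by these compounds, what an amine or a carboxylic acid on this ring would do remains open.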